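Trading one aromatic ester group for a longer one

The compounds below may be only part of what the source reports. "The series", "measured", "known", "first", "only" and "open" are said of these compounds alone.

In a functional assay on HepG2 cells (Homo sapiens) for cytotoxicity, read by MTT assay (a higher number here means a weaker inhibitor, a lower number a stronger inhibitor), compound 1 `COc1ccc(/C=C/C(=O)c2ccc(OC)c3c2OC(C)(C)C=C3)cc1OCCCN(C)C` gives 5550 nM, compound 2 `C=CC(=O)Oc1cc(/C=C/C(=O)c2ccc(OC)c3c2OC(C)(C)C=C3)ccc1OC` gives 160 nM, and compound 3 `COc1cccc(C(=O)Oc2cc(/C=C/C(=O)c3ccc(OC)c4c3OC(C)(C)C=C4)ccc2OC)c1` gives 870 nM, so compound 3 sits in the middle of the three. The next molecule, compound 4 `COc1ccc(/C=C/C(=O)Oc2cc(/C=C/C(=O)c3ccc(OC)c4c3OC(C)(C)C=C4)ccc2OC)cc1`, changes one group of compound 3: 2-(4-methoxyphenyl)ethenyl in place of 3-methoxyphenyl on a carbonyl carbon. In words, 2-(4-methoxyphenyl)ethenyl stands in place of 3-methoxyphenyl on a carbonyl carbon.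

The most relevant evidence is the earlier change at that same carbon, a 5.4-fold higher number from compound 2 to compound 3 (0.74 log units; beyond the scatter), where 3-methoxyphenyl replaced vinyl. The steps of a 35-fold lower number from compound 1 to compound 2 (1.54 log units; beyond the scatter) and a 6.4-fold lower number from compound 1 to compound 3 (0.80 log units; beyond the scatter) bear on it less, since both replace 3-(dimethylamino)propyl, which is absent here. The entering group holds both a double bond outside aromatic rings, as vinyl does, and an aromatic ring, as 3-methoxyphenyl does. A result between compounds 2 and 3, nearer compound 3, therefore seems reasonable. In this assay, the expected change is small and leans lower: a 1.5-fold lower number from compound 3 to compound 4 (0.16 log units; within the scatter). For compound 4, the estimated value is 600 nM, with an expected range from 200 nM to 1800 nM.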

Compound 4, half-maximal inhibitory concentration: 430 nM
Compound 4: the middle estimate sits 1.4-fold (0.14 log units) above what was measured; low and high end bracket the measured number.
By their numbers in this assay, from the lowest: compound 2; then compound 4; then compound 3; then compound 1.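

In this assay, the entering 2-(4-methoxyphenyl)ethenyl group gives a lower number than 3-methoxyphenyl at this carbonyl carbon (a 2.0-fold lower number from compound 3 to compound 4 (0.31 log units; beyond the scatter)), so a group holding an aromatic ring can differ measurably from another such group here. Vinyl still gives the lower number (a 2.7-fold higher number from compound 2 to compound 4 (0.43 log units; beyond the scatter)), while compound 4 keeps a clear margin over the 3-(dimethylamino)propyl compound (a 13-fold lower number from compound 1 to compound 4 (1.11 log units; beyond the scatter)), as compounds 2 and 3 also do. Nothing measured here explains these differences.

Still open, from the compounds shown here alone, is which difference goes with the lower number, the added double bond or the methoxy group's place on the ring, as both change together in this step. A 4-methoxyphenyl group on the same carbonyl carbon would separate the two, and an amine at the end of the entering group remains an untested question in the compounds shown.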